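Adding a Third Methoxy Group to Compound 2

A few compounds are considered here, and "the series" means these few. Any claim that something is new, unique, unknown or untested is made for them only; others in the source may bear on it.

Compound 2 `COc1ccc(C2CC(c3cc(Cl)c(C)cc3O)=NN2c2ccc(S(N)(=O)=O)cc2)cc1OC` and compound 1 `Cc1cc(O)c(C2=NN(c3ccc(S(N)(=O)=O)cc3)C(c3ccccc3Cl)C2)cc1Cl` share one core and differ only at the saturated ring carbon. In a functional assay on HCT-116 cells (Homo sapiens) for antiproliferative activity, with a stated time of 48 h (on this read-out higher numbers stand for weaker inhibition of growth and lower numbers for stronger inhibition of growth), compound 1 gives 1760 nM, and compound 2 gives 1720 nM; the two values lie within the usual scatter of each other, as the step of a 1.0-fold lower number from compound 1 to compound 2 (0.01 log units; within the scatter) shows. Compound 3 `COc1ccc(C2CC(c3cc(Cl)c(C)cc3O)=NN2c2ccc(S(N)(=O)=O)cc2)c(OC)c1OC` carries methoxy in place of hydrogen on an aromatic carbon. Going by the values given here, the only measured step, the exchange of the whole aryl group, moved nothing beyond the scatter, so the smaller change here is expected to give a 1.0-fold lower number from compound 2 to compound 3 (0.01 log units; within the scatter). Compound 3 is therefore estimated at 1700 nM, within 800 nM to 3600 nM.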

Compound 3, concentration for 50% growth inhibition: 1630 nM
Compound 3: the middle estimate sits 1.0-fold (0.02 log units) above what was measured; the range from low to high includes it.
By their numbers in this assay, from the lowest: compounds 3, 2 and 1 (each within the scatter of the next).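

In this assay, adding a methoxy group at this position, ortho to a large group and to a methoxy group, gives a 1.1-fold lower number from compound 2 to compound 3 (0.02 log units; within the scatter), so this aromatic carbon can carry the extra group without a shift beyond the scatter. Exchanging the whole aryl group gives a 1.1-fold lower number from compound 1 to compound 3 (0.03 log units; within the scatter), so all three aryl groups seen so far give values within the scatter of one another. Nothing shown here gives a reason for this. As far as these compounds go, whether an amine or a carboxylic acid at this position would move the number beyond the scatter remains open. The same holds for a longer chain, such as ethoxy, in place of the methoxy group.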